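The source may hold more compounds than are shown below. What is called first, only, known or untested is meant among the compounds shown, and "the series" means these compounds.

Of the compounds shown here, three built on one shared core have been tested in an assay on membranes from HEK293 cells for displacement of a labelled ligand from adenosine receptor A2b (Homo sapiens), read by scintillation counting, with a stated time of 30 min, tested at 1 uM; on this read-out lower numbers stand for less inhibition and higher numbers for more inhibition at the one concentration tested (going by the name of the read-out). Compound 1 `COC(=O)C1=C(C)NC(=O)NC1c1cccs1` gives 19%. Compound 2 `CC1=C(C(=O)OC(C)(C)C)C(c2ccsc2)NC(=O)N1` gives 47%, and compound 3 `CCCOC(=O)C1=C(C)NC(=S)NC1c1ccco1` gives 46%. Among these three numbers compound 3 stands second highest. Its value and that of compound 2 lie within the usual scatter of each other, so nothing separates them, while compound 1 sits lower by a gap beyond the scatter, so compound 3 inhibits more than compound 1 at the concentration tested.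

Compound 4 `CC1=C(C(=O)OC(C)(C)C)C(c2ccco2)NC(=S)N1` has not yet been measured. It differs from compound 3 in one place: tert-butyl in place of propyl on an oxygen next to a carbonyl group. Among the compounds with values here, no pair of measured compounds shows this change on its own, so no measured step can be leaned on. Compound 2 also carries tert-butyl on an oxygen next to a carbonyl group, and in this assay compound 2 gives 47%, close to the number for compound 3, but compound 2 differs from compound 3 in other places too, so this is only a hint. The expected step from compound 3 to compound 4 is a number 2 percentage points higher from compound 3 to compound 4 (within the scatter), within the scatter and with no clear direction. Compound 4 is therefore estimated at 48%, in a range from 30% to 65%.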

Compound 4, a percentage reported as inhibition, at one concentration (the size of the read-out at that concentration, not a potency): 9%
Estimate against measurement, compound 4: 39 percentage points above; the whole stated range lies above it.
By their numbers in this assay, from the lowest: compounds 4 and 1 (each within the scatter of the next); then compounds 3 and 2 (each within the scatter of the next).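

In this assay, replacing propyl with tert-butyl on an oxygen next to a carbonyl group gives a number 37 percentage points lower from compound 3 to compound 4 (beyond the scatter), a large step for a swap of one small carbon chain for another. Within the data shown here, this is the first direct look at this place, since no two earlier compounds differed in one place only, and it shows that, with the rest of compound 3 kept, the read-out depends strongly on which of these two chains the oxygen carries. Nothing measured here explains why this change has so large an effect.

As far as these compounds go, whether an isopropyl or a butyl group on the same oxygen would give a number like that of compound 3 or that of compound 4 remains open, as does the result of a carboxylic acid at this place. This single pair also cannot show whether the same change would give a step of similar size when other groups on the shared core are different.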